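A few compounds are considered here, and "the series" means these few. Any claim that something is new, unique, unknown or untested is made for them only; others in the source may bear on it.

Working notes on the series in an ADME assay on MT2 cells (Homo sapiens) for cytotoxicity, read by XTT assay, with a stated time of 4 days; a higher number here means that more compound is tolerated, a lower number that less compound is tolerated.

Three compounds have been run. Compound 1 `Cc1ccc(-c2c3c(nc(C)c2[C@H](OC(C)(C)C)C(=O)O)CCN(CCCc2ccccc2)C3)cc1` is recorded only as a limit in this assay, > 40000 nM. Compound 3 `Cc1ccc(-c2c(C(OC(C)(C)C)C(=O)O)c(C)nc3ccccc23)cc1` is likewise recorded only as a limit, > 40000 nM. Compound 2 `Cc1nc2c(c(-c3cc(F)c4c(c3C)CCCO4)c1[C@H](OC(C)(C)C)C(=O)O)CN(CCCc1ccc(F)cc1)CC2`, the parent of the step followed here, also reaches only a limit in this assay, > 40000 nM. Compound 2 therefore stands where every other measured compound stands: all values shown are limits, and nothing separates it from compound 1 or compound 3 on the numbers, because of the limit of > 40000 nM in this assay, at which 3 of the 3 values shown sit.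

Compound 4 `Cc1ccc(CCCN2CCc3nc(C)c([C@H](OC(C)(C)C)C(=O)O)c(-c4cc(F)c5c(c4C)CCCO5)c3C2)cc1F` is the compound not yet measured. It differs from compound 2 as follows (3-fluoro-4-methylphenyl in place of 4-fluorophenyl on a saturated chain carbon, three bonds along the chain from an amine nitrogen in a ring).

For the measured compounds named here, no step between measured compounds is known, so no measured size of step guides this one. Given that the whole set sits at the limit, the change is expected to move tolerance by nothing beyond the scatter, and the step of a number no higher from compound 2 to compound 4 (the limit leaves the size open) is expected to be essentially flat. Compound 4 is estimated at 40000 nM, with a range of 20000 nM to 80000 nM, most likely again reported only as a limit.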

Compound 4, half-maximal cytotoxic concentration: > 40000 nM
Compound 4: a limit, no number; the forecaster's own chance of this, stated with the estimate: 85%; the middle value sits exactly at the limit.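

Compound 2 and compound 4 are both recorded only as limits, so no step can be read between them: the limit of > 40000 nM in this assay, at which 4 of the 4 values shown sit.

The compounds shown leave open the concentration at which any of them would reach half-maximal cytotoxicity in this assay, and whether 3-fluoro-4-methylphenyl in place of 4-fluorophenyl changes tolerance at all.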